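Extending the methoxy arm of compound 1 with a hydroxypentyl chain

The compounds below may be only part of what the source reports. "The series", "measured", "known", "first", "only" and "open" are said of these compounds alone.

Measured compounds:
- compound 1, `COc1cc(CNc2nc3c(N)ncnc3n2[C@@H]2O[C@H](CO)[C@@H](O)[C@H]2O)ccc1-c1ccccc1`: 1300 nM
- compound 2, `CC(C)Oc1cc(CNc2nc3c(N)ncnc3n2[C@@H]2O[C@H](CO)[C@@H](O)[C@H]2O)ccc1-c1ccccc1`: 10400 nM

Going by the values given here, in an assay on COS-7 cells for inhibition of sodium/nucleoside cotransporter 2 (Homo sapiens), read by scintillation counting (on this read-out lower numbers stand for stronger inhibition and higher numbers for weaker inhibition), compound 1 gives 1300 nM, the lowest of the two numbers recorded; its only neighbour is compound 2, reached by an 8.0-fold higher number from compound 1 to compound 2 (0.90 log units; beyond the scatter). Compound 3, `Nc1ncnc2c1nc(NCc1ccc(-c3ccccc3)c(OCCCCCO)c1)n2[C@@H]1O[C@H](CO)[C@@H](O)[C@H]1O`, has not been measured. It differs from compound 1 by 4-hydroxybutyl in place of hydrogen on a saturated chain carbon bound to an oxygen on an aromatic ring, so the methoxy of compound 1 becomes a (5-hydroxypentyl)oxy group. Among the compounds with values here, the one measured step that bears on this, the move from compound 1 to compound 2, enlarged the same alkoxy group and weakened inhibition by a modest amount, beyond the scatter. The new chain is longer still but unbranched and carries a hydroxyl, for which no comparison exists. Compound 3 is therefore expected to be somewhat weaker than compound 1, by an estimated 3.1-fold higher number from compound 1 to compound 3 (0.49 log units; beyond the scatter), with an estimated 4000 nM and a range from 1000 nM to 20000 nM.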

Compound 3, half-maximal inhibitory concentration: 1600 nM
The estimate for compound 3 lay 2.5-fold (0.40 log units) above the measured number, and the stated range covers the measured number.
By their numbers in this assay, from the lowest: compounds 1 and 3 (each within the scatter of the next); then compound 2.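

In this assay, the oxygen on the aromatic ring can carry a much larger group than methyl without a measurable loss: 4-hydroxybutyl in place of hydrogen on the methoxy carbon gives a 1.2-fold higher number from compound 1 to compound 3 (0.09 log units; within the scatter). Putting 5-hydroxypentyl in place of isopropyl on the same oxygen gives a 6.5-fold lower number from compound 2 to compound 3 (0.81 log units; beyond the scatter), so the loss seen with isopropyl does not extend to every larger group at this position. Nothing available explains why these two groups differ.

The compounds shown leave open whether the hydroxyl of the 5-hydroxypentyl group or its unbranched chain sets compound 3 apart from compound 2. A plain pentyl group would separate those two features, while a pentyl chain carrying an amine or a carboxylic acid, or a longer chain, would show how far this freedom reaches.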